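This account rests on a few compounds, and the source may have more. Where it says the series, first, only, none or still open, it means among the compounds named here.

Series notes. In a functional assay on IMR-32 cells (Homo sapiens) for cytotoxicity, read by sulforhodamine B assay, with a stated time of 48 h (on this read-out higher numbers stand for weaker inhibition and lower numbers for stronger inhibition), compound 1 `CC(=O)N1N=C(c2cccc3ccccc23)CC1c1cccc(Cl)c1Cl` gives 22100 nM, compound 2 `CC(=O)N1N=C(c2cccc3ccccc23)CC1c1cccc(Br)c1` gives 11900 nM and compound 3 `O=CCN1N=C(c2ccc3ccccc3c2)CC1c1cccc(Cl)c1Cl` gives 16900 nM. Compound 3 stands second highest of the three numbers; its gaps to compound 1 and to compound 2 both lie within the scatter. Compound 4 `COc1ccc(C2CC(c3ccc4ccccc4c3)=NN2CC=O)cc1` differs from compound 3 by 4-methoxyphenyl in place of 2,3-dichlorophenyl on a saturated ring carbon. Going by the values given here, the only measured change at that saturated ring carbon is a 1.9-fold lower number from compound 1 to compound 2 (0.27 log units; within the scatter), which stayed within the scatter. On that single precedent the expected change in this assay is a 1.0-fold higher number from compound 3 to compound 4 (0.00 log units; within the scatter), which is to say no step beyond the scatter in either direction. For compound 4 the estimated value in this assay is 17000 nM, with a range from 6000 nM to 48000 nM.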

Compound 4, half-maximal inhibitory concentration: 4120 nM
The estimate for compound 4 lay 4.1-fold (0.62 log units) above the measured number; the measured number lies below the stated range.
By their numbers in this assay, from the lowest: compound 4; then compounds 2, 3 and 1 (each within the scatter of the next).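

In this assay, going by these compounds alone, the saturated ring carbon turns out to be able to shift the number: 4-methoxyphenyl in place of 2,3-dichlorophenyl gives a 4.1-fold lower number from compound 3 to compound 4 (0.61 log units; beyond the scatter) and so goes beyond the scatter, which the only earlier step at this carbon did not. No measurement on hand accounts for this step. Still open, as far as these compounds go, is whether the gain goes with the methoxy group or with the loss of the two chlorines, which an unsubstituted phenyl or a 4-hydroxyphenyl at this carbon would help separate.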